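The compounds below may be only part of what the source reports. "The series", "measured", "known", "first", "only" and "open" are said of these compounds alone.

Measured so far in a physicochemical assay for lipophilicity, at pH 7.4; on this read-out higher numbers stand for higher lipophilicity and lower numbers for lower lipophilicity:
compound 1 `COc1cccc(C(=O)NCc2c(C)cc(C)[nH]c2=O)c1F` gives 1.4
compound 2 `Cc1cc(C)c(CN2CCc3ccc(OC(C)C)cc3C2=O)c(=O)[nH]1` gives 2.5
compound 3 `Cc1cc(C)c(CN2CCc3c(Cl)cc(-c4c(C)n[nH]c4C)c(Cl)c3C2=O)c(=O)[nH]1` gives 3.4

Compound 1 has the lowest number of the three, and compounds 2 and 3 both lie above it by more than the scatter. Compound 4 `COc1cccc(C(=O)NCc2c(C)cc(C)[nH]c2=O)c1C` has not yet been measured. It differs from compound 1 by a single swap, methyl in place of fluoro on an aromatic carbon (methyl in place of fluoro on an aromatic carbon, ortho to a large group and ortho to a methoxy group). Within the data shown here, no measured pair shows this swap, so the expectation is only a rough one. A small rise in this assay is expected, close to the edge of the scatter, with an estimated a number 0.30 log units higher from compound 1 to compound 4 (within the scatter) as the outcome. Compound 4 is estimated at 1.7 (expected range 1.3 to 2.1).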

Compound 4, distribution coefficient: 1.5
For compound 4 the middle estimate is 0.20 log units above the measured one; the range from low to high includes it.
By their numbers in this assay, from the lowest: compounds 1 and 4 (each within the scatter of the next); then compound 2; then compound 3.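

In this assay, among these compounds, the swap of methyl in place of fluoro, on an aromatic carbon ortho to a large group and ortho to a methoxy group, gives a number 0.10 log units higher from compound 1 to compound 4 (within the scatter) and is the first single-place change that can be read here. On the core of compound 1, this read-out therefore does not separate these two small groups at this position. Nothing at hand gives a reason for this result. As far as these compounds go, whether an amine, a carboxylic acid or a longer chain at this carbon would stay as close remains open. So does whether the same swap would behave alike on another core.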